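The source may hold more compounds than are shown below. What is called first, only, known or untested is meant among the compounds shown, and "the series" means these compounds.

In an assay on membranes from Jurkat cells for displacement of a labelled ligand from Sigma non-opioid intracellular receptor 1 (Homo sapiens), read by scintillation counting, with a stated time of 2 h (a lower number here means a stronger inhibitor, a higher number a weaker inhibitor), the three measured compounds stand as follows:

- compound 1, `Cn1nc(CN2CCCC2)nc1-c1ccc(C2CCCCC2)cc1`: 20 nM
- compound 2, `Cn1nc(CN2CCCC2)nc1-c1cccc(C2(C(F)(F)F)CC2)c1`: 32 nM
- compound 3, `CC(C)(C)c1ccc(-c2nc(CN3CCCC3)nn2C2CC2)cc1`: 14 nM

Compound 3 has the lowest number of the three in this assay. Its gap to compound 1 lies within the usual scatter of repeated measurements, so no order can be read between the two; its gap to compound 2 lies beyond the scatter. Within the data shown here, no two of the measured compounds differ in only one place, so no single step can be taken from the numbers themselves.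

Compound 4, `CCn1nc(CN2CCCC2)nc1-c1ccc(C(C)(C)C)cc1`, is not yet measured. It differs from compound 3 in one place: ethyl in place of cyclopropyl on an aromatic nitrogen. Both compound 1 and compound 2 carry a methyl group on that same aromatic nitrogen and give numbers close to compound 3, which suggests that a small alkyl group there is tolerated. The step from compound 3 to compound 4 is therefore expected to be small, most likely within the scatter, a 1.3-fold higher number from compound 3 to compound 4 (0.11 log units; within the scatter). For compound 4 in this assay the estimate is 18 nM, with a range from 8 nM to 45 nM.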

Compound 4, inhibition constant: 4.8 nM
Beside the measured number, compound 4's estimate is 3.8-fold (0.57 log units) above it, and the stated range ends above it.
By their numbers in this assay, from the lowest: compound 4; then compounds 3, 1 and 2 (each within the scatter of the next, the first and the last beyond it).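

Among these compounds, the pair gives the first reading of this position with everything else held constant: in this assay, replacing cyclopropyl with ethyl on the aromatic nitrogen gives a 2.9-fold lower number from compound 3 to compound 4 (0.46 log units; beyond the scatter). The group on this nitrogen therefore affects the number, and here the open ethyl with no ring gives the lower value, a modest step that compounds 1 and 2 could not show, as they carry methyl there but also differ elsewhere. No measurement shown bears on why the number falls.

Going by these compounds, whether the ring itself or only the size of the group matters stays open, as a single pair cannot separate the two. On these data alone, how methyl, a longer propyl chain, a branched isopropyl group or a chain ending in an amine would read on this nitrogen in the same compound also remains unknown.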